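Cyclohexyl in place of tert-butylphenyl on the shared core

This account rests on a few compounds, and the source may have more. Where it says the series, first, only, none or still open, it means among the compounds named here.

Three compounds have so far been measured in an ADME assay on HepG2 cells (Homo sapiens) for cytotoxicity, read by luminescence, CellTiter-Glo and ATP content, with a stated time of 72 h; on this read-out higher numbers stand for an effect only at larger amounts of compound and lower numbers for an effect already at smaller amounts:

Compound 1 `COc1cccc(Oc2ccc3c(NCCCNCc4cccc(OC)c4O)ccnc3c2)c1`: 5300 nM
Compound 2 `COc1cccc(CNCCCNc2ccnc3cc(CC(C)C)ccc23)c1O`: 2920 nM
Compound 3 `COc1cccc(CNCCCNc2ccnc3cc(-c4ccc(C(C)(C)C)cc4)ccc23)c1O`: 690 nM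

Compound 3 gives the lowest number of the three. The steps of a 7.7-fold lower number from compound 1 to compound 3 (0.89 log units; beyond the scatter) and a 4.2-fold lower number from compound 2 to compound 3 (0.63 log units; beyond the scatter) both lie beyond the scatter, whereas a 1.8-fold lower number from compound 1 to compound 2 (0.26 log units; within the scatter) does not.

Compound 4 `COc1cccc(CNCCCNc2ccnc3cc(C4CCCCC4)ccc23)c1O` differs from compound 3 in one place: cyclohexyl in place of 4-(tert-butyl)phenyl on an aromatic carbon. The step that bears on this is a 4.2-fold lower number from compound 2 to compound 3 (0.63 log units; beyond the scatter), in which the larger group gave the lower number. The cyclohexyl of compound 4 is smaller than the 4-(tert-butyl)phenyl it replaces and larger than the isobutyl of compound 2. A modest rise beyond the scatter is therefore expected in this assay, namely a 2.2-fold higher number from compound 3 to compound 4 (0.34 log units; beyond the scatter). Compound 4 is estimated at 1500 nM, with a range of 600 nM to 4000 nM.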

Compound 4, half-maximal effective concentration: 1080 nM
Compound 4: middle estimate off by 1.4-fold (0.14 log units), on the high side; measured number inside the range.
By their numbers in this assay, from the lowest: compounds 3 and 4 (each within the scatter of the next); then compounds 2 and 1 (each within the scatter of the next).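

Replacing the aromatic ring of 4-(tert-butyl)phenyl with the non-aromatic cyclohexyl, which has fewer heavy atoms, hardly moves the result in this assay (a 1.6-fold higher number from compound 3 to compound 4 (0.19 log units; within the scatter)), so at this position an aromatic ring is not required for a low number. Cyclohexyl still stands clear of isobutyl (a 2.7-fold lower number from compound 2 to compound 4 (0.43 log units; beyond the scatter)) and of 3-methoxyphenoxy (a 4.9-fold lower number from compound 1 to compound 4 (0.69 log units; beyond the scatter)). No measurement at hand explains these steps. On these data alone, what an amine or a carboxylic acid on the cyclohexyl ring would give at this position remains open.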